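The source may report more compounds than this note shows. Statements on the series, on what has been measured and on what is new or still open speak of the compounds shown alone.

Measured compounds:
compound 1, `COc1ccc(-c2cc(/C=C/C(=O)c3ccc(N)cc3)[nH]n2)cc1` — 81%
compound 2, `COc1ccc(C(=O)/C=C/c2cc(-c3cc(OC)c(OC)c(OC)c3)n[nH]2)cc1OC` — 71%
compound 3, `COc1ccc(-c2cc(/C=C/C(=O)c3ccc(N)cc3)[nH]n2)cc1OC` — 89%

Of the compounds shown here, three have been measured so far in a functional assay on PC-3 cells (Homo sapiens) for cytotoxicity, read by sulforhodamine B assay, with a stated time of 48 h, tested at 1 uM; a higher number here means a weaker effect of the compound at the concentration tested, a lower number a stronger effect. Compound 1 and compound 3 share one core, and the change between them is methoxy in place of hydrogen on an aromatic carbon. That step is a number 8 percentage points higher from compound 1 to compound 3 (within the scatter), so the two numbers cannot be told apart here. Compound 2 is built on a different core; how it differs from compound 1 is not broken down here. What the values show is that compound 2 and compound 1 lie within the scatter of each other, while compound 3 gives a higher number than compound 2, a gap beyond the scatter.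

Compound 4, `COc1cc(C(=O)/C=C/c2cc(-c3cc(OC)c(OC)c(OC)c3)n[nH]2)cc(OC)c1OC`, has not been measured. It differs from compound 2 by methoxy in place of hydrogen on an aromatic carbon. For the measured compounds named here, this is the same kind of change as the one from compound 1 to compound 3, not the same change: around the place of the change in compound 4 the added group is also meta to a methoxy group, which is not so in compound 3. The only step of this kind in the set, from compound 1 to compound 3, stayed within the scatter, so compound 4 is expected to sit close to compound 2, with an estimated step of a number 7 percentage points higher from compound 2 to compound 4 (within the scatter) that rests on a number 8 percentage points higher from compound 1 to compound 3 (within the scatter). On that basis compound 4 is estimated at 78% in this assay, most likely between 62% and 92%.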

Compound 4, a percentage reported as activity, at one concentration (the size of the read-out at that concentration, not a potency): 74%
Beside the measured number, compound 4's estimate is 4 percentage points above it, and the stated range covers the measured number.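

In this assay the new step is a number 3 percentage points higher from compound 2 to compound 4 (within the scatter) for methoxy in place of hydrogen on an aromatic carbon, so on the core of compound 2, as on the core of compound 1, the added methoxy gives no number that can be told apart from that of the parent compound. This does not show that the change would behave alike on other cores or at other places on the ring: it rests on two pairs only, read at a single concentration in one cell line, and the surroundings of the change differ, with the added group in compound 4 also meta to a methoxy group, which is not so in compound 3. Within those limits, the change carries from one core to the other without a detectable difference between the two steps: the same change on two cores in this assay, a number 8 percentage points higher (within the scatter) from compound 1 to compound 3 and a number 3 percentage points higher (within the scatter) from compound 2 to compound 4, 5 percentage points apart, within the scatter of two such steps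

The compounds shown leave open whether a group other than methoxy at that place, such as chloro, hydroxy or trifluoromethyl, would give a step beyond the scatter. They also leave open whether replacing a methoxy group already present with hydrogen or a longer chain such as ethoxy would change the number on either core.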